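The source may report more compounds than this note shows. Statements on the series, on what has been measured and on what is new or still open speak of the compounds shown alone.

Measured compounds:
compound 1, `Nc1ccccc1NC(=O)c1ccc(CSC(=S)N2CCN(c3cccnc3)CC2)cc1`: 66.2%
compound 2, `CN1CCN(C(=S)SCc2ccc(C(=O)Nc3ccccc3N)cc2)CC1`: 52.6%

In a functional assay on HeLa cells (Homo sapiens) for antiproliferative activity, read by CCK-8 assay, with a stated time of 72 h, tested at 2 uM (a higher number here means a stronger effect of the compound at the concentration tested, a lower number a weaker effect), compound 2 stands lowest of the two numbers; its nearest neighbour is compound 1, and the two are separated by a number 13.6 percentage points lower from compound 1 to compound 2 (beyond the scatter). Compound 3, `Nc1ccccc1NC(=O)c1ccc(CSC(=S)N2CCN(c3ccccc3F)CC2)cc1`, is not yet measured. It differs from compound 2 by 2-fluorophenyl in place of methyl on an amine nitrogen in a ring. Among the compounds with values here, the only measured step that bears on this change is a number 13.6 percentage points lower from compound 1 to compound 2 (beyond the scatter), where an aromatic ring on the same ring nitrogen went with the higher number. A step upward of roughly that size is therefore expected in this assay, and the expected step is a number 12.4 percentage points higher from compound 2 to compound 3 (beyond the scatter). For compound 3 the estimated value is 65%, within an expected range of 52% to 78%.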

Compound 3, a percentage reported as inhibition, at one concentration (the size of the read-out at that concentration, not a potency): 17.5%
The estimate for compound 3 lay 47.5 percentage points above the measured number, outside the stated range (below it).
By their numbers in this assay, from the lowest: compound 3; then compound 2; then compound 1.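

In this assay, an aromatic ring on this ring nitrogen does not by itself go with the higher number: there is a number 35.1 percentage points lower from compound 2 to compound 3 (beyond the scatter), opposite in direction to the change from methyl to pyridin-3-yl. Which aromatic ring sits there matters, with a number 48.7 percentage points lower from compound 1 to compound 3 (beyond the scatter). No available evidence accounts for this reversal.

Open, as far as these compounds go, is whether plain phenyl or a benzyl group on the same ring nitrogen would fall nearer compound 1 or compound 3. That would help separate the fluorine from the carbon-only ring.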